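Swapping the ketone's aryl group in a trimethoxyphenyl series

The compounds below may be only part of what the source reports. "The series", "measured", "known", "first", "only" and "open" are said of these compounds alone.

Measured compounds:
compound 1 `COc1cc(-c2nnc3n2NC(c2ccco2)C(C(=O)c2cccs2)S3)cc(OC)c1OC` gives 64100 nM
compound 2 `COc1cc(-c2nnc3n2NC(c2cccs2)C(C(=O)c2ccc(C)cc2)S3)cc(OC)c1OC` gives 3700 nM
compound 3 `COc1cc(-c2nnc3n2NC(c2cccs2)C(C(=O)c2ccccc2)S3)cc(OC)c1OC` gives > 100000 nM

In a functional assay on HepG2 cells (Homo sapiens) for cytotoxicity, read by MTT assay, with a stated time of 48 h (a lower number here means a stronger inhibitor, a higher number a weaker inhibitor), compound 1 gives 64100 nM, the highest of the two plain numbers shown. Compound 2 gives 3700 nM in this assay. For compound 3 the assay reports only a limit, > 100000 nM; this is the limit of > 100000 nM in this assay, at which 1 of the 3 values shown sits, and not a measured number.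

Compound 4 `COc1ccc(C(=O)C2Sc3nnc(-c4cc(OC)c(OC)c(OC)c4)n3NC2c2ccco2)cc1` differs from compound 1 in one place: 4-methoxyphenyl in place of thiophen-2-yl on a carbonyl carbon. Among the measured compounds shown here, only one measured step exists, an at least 27-fold higher number from compound 2 to compound 3 (1.43 log units; beyond the scatter), where a methyl on an aromatic carbon is replaced by hydrogen. For the measured compounds named here, that step does not concern the same change as the one from compound 1 to compound 4, but it shows that a small change on an aromatic ring can move the number in this assay by a large amount. Compound 2, which carries a methyl-bearing phenyl on its carbonyl carbon, gives the lowest plain number, while compound 1 with a thiophen-2-yl there gives the highest. On that slender basis compound 4, with a 4-methoxyphenyl on the carbonyl carbon, is expected to give a lower number than compound 1, a step of a 4.3-fold lower number from compound 1 to compound 4 (0.63 log units; beyond the scatter). Compound 4 is therefore estimated at 15000 nM, with a range from 3000 nM to 70000 nM.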

Compound 4, half-maximal inhibitory concentration: > 100000 nM
Compound 4: only a limit was reported; the forecaster's own chance of this, stated with the estimate: 10%; at least 6.6-fold (0.82 log units) between middle value and limit.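

In this assay compound 4 gives > 100000 nM, which is a limit of the assay and not a number. Among the compounds shown here, this is the first direct reading of the group on the carbonyl carbon, since compound 1 and compound 4 differ only there: 4-methoxyphenyl in place of thiophen-2-yl gives an at least 1.5-fold higher number from compound 1 to compound 4 (0.19 log units; that floor lies within the scatter), so this swap brought no measurable gain, and a para-free reading of the data is that a six-membered aromatic ring of carbon only did not lower the number in this frame. How far the two compounds really lie apart cannot be told, because compound 4 has only a limit and the printed step is merely a floor: the limit of > 100000 nM in this assay, at which 2 of the 4 values shown sit.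

The compounds shown leave open whether a group on the carbonyl carbon other than these two, such as a phenyl ring carrying an amine or a carboxylic acid, would lower the number with the rest of compound 1 unchanged. They also leave open whether a longer chain in place of the methoxy on that phenyl ring would move the number at all.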